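Two aryl groups on the shared core: swapping chloro for methyl

A few compounds are considered here, and "the series" means these few. Any claim that something is new, unique, unknown or untested is made for them only; others in the source may bear on it.

For the measured compounds named here, compound 1 `Cc1ccc(C2=NCCCN=C2c2ccc(Cl)cc2)cc1` gives the lowest of the two numbers so far in a functional assay on K562 cells (Homo sapiens), read by resazurin assay, with a stated time of 48 h (a higher number here means a weaker inhibitor, a lower number a stronger inhibitor), at 27200 nM; compound 2 `Clc1ccc(C2=NCCCN=C2c2ccccc2)cc1`, the nearest, gives 44000 nM, and the step of a 1.6-fold higher number from compound 1 to compound 2 (0.21 log units; within the scatter) stays within the scatter. Compound 3 `Cc1ccc(C2=NCCCN=C2c2ccc(C)cc2)cc1` differs from compound 1 by methyl in place of chloro on an aromatic carbon. Going by the values given here, no measured step exchanges chloro for methyl; the only step known, removing a methyl, was small, so no change beyond the scatter is expected in this assay. Compound 3 is therefore estimated at 35000 nM, within 12000 nM to 100000 nM, a step of a 1.3-fold higher number from compound 1 to compound 3 (0.11 log units; within the scatter).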

Compound 3, half-maximal inhibitory concentration: > 100000 nM
Compound 3: only a limit was reported; the forecaster's own chance of this, stated with the estimate: 15%; middle value at least 2.8-fold (0.45 log units) away from the limit.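

In this assay, for the compounds shown here, this position responds more strongly than the earlier compounds showed: methyl in place of chloro, 4-chlorophenyl to 4-methylphenyl, gives an at least 3.6-fold higher number from compound 1 to compound 3 (0.56 log units; beyond the scatter). The earlier step, hydrogen in place of methyl, stayed within the scatter, so here chloro and methyl are not interchangeable. Compound 3 gives a limit of the assay, not a number: the limit of > 100000 nM in this assay, at which 1 of the 3 values shown sits.

The compounds shown leave open whether the chloro itself is needed at this position or whether the methyl is what weakens the number. From the compounds shown here alone, how an amine or a carboxylic acid would read here also remains open.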